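Acetyl to pyridazin-3-yl on a long-lasting compound

The source may hold more compounds than are shown below. What is called first, only, known or untested is meant among the compounds shown, and "the series" means these compounds.

Measured in an ADME assay on cells (Hepatocyte, Rattus norvegicus) for metabolic stability; a lower number here means that the compound disappears faster, a higher number that the compound lasts longer:
Compound 1 `O=C(C1CCN(c2ccncn2)CC1)N1N=CC[C@H]1c1ccccc1`: < 0.4 h (a limit)
Compound 2 `Cc1nnc(N2CCC(C(=O)N3N=CC[C@H]3c3ccccc3)CC2)o1`: 2.88 h
Compound 3 `CC(=O)N1CCC(C(=O)N2N=CC[C@H]2c2ccccc2)CC1`: > 3.11 h (a limit)

Compound 3 reads > 3.11 h, which is a limit and not an exact number. The gap to its neighbour, an at least 1.0-fold higher number from compound 2 to compound 3 (0.03 log units; that floor lies within the scatter), stays within the scatter. Compound 4 `O=C(C1CCN(c2cccnn2)CC1)N1N=CC[C@H]1c1ccccc1` puts pyridazin-3-yl in place of acetyl on an amine nitrogen in a ring. The nearest guide is compound 1, which carries pyrimidin-4-yl on that nitrogen. Going an at least 7.7-fold higher number from compound 1 to compound 3 (0.89 log units; beyond the scatter) was a step beyond the scatter, and so was going an at least 7.2-fold higher number from compound 1 to compound 2 (0.85 log units; beyond the scatter). From the compounds shown here alone, a drop of similar size is therefore expected in this assay, though pyridazin-3-yl itself is untested. As a step, the expected change is an at least 5.6-fold lower number from compound 3 to compound 4 (0.75 log units; beyond the scatter). For compound 4 the estimated half-life is 0.55 h, within an expected range of 0.2 h to 1.5 h.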

Compound 4, half-life: < 0.517 h
Compound 4: only a limit was reported; the forecaster's own chance of this, stated with the estimate: 40%; at least 1.0-fold (0.02 log units) between middle value and limit.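

In this assay, pyridazin-3-yl in place of acetyl on this amine nitrogen gives an at least 6.0-fold lower number from compound 3 to compound 4 (0.77 log units; beyond the scatter), and in place of 5-methyl-1,3,4-oxadiazol-2-yl it gives an at least 5.5-fold lower number from compound 2 to compound 4 (0.74 log units; beyond the scatter). The short half-life of compound 1 is therefore not confined to pyrimidin-4-yl: compound 4, with another six-membered aromatic ring with 2 hetero atoms, also falls well short of compound 2 and compound 3. The step from compound 1 to compound 4 cannot be read: both values are limits.

Still open, from the compounds shown here alone, is whether a plain phenyl ring on this nitrogen would give a similarly short half-life.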